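The source may report more compounds than this note shows. Statements on the series, on what has been measured and on what is new or still open speak of the compounds shown alone.

Three compounds have been tested in an assay on LX2 cells for inhibition of COL1A1 promoter (Homo sapiens), read by a luciferase reporter, with a stated time of 24 h, tested at 20 uM; a lower number here means a weaker effect, a higher number a stronger effect of the compound at the concentration tested:

Compound 1 `Cc1cc(OCCCCCCC[N+]23CCN(CC2)CC3)ccc1-n1cc(C(=O)Nc2cc(F)cc(F)c2)c(=O)c2ccc(N(C)C)nc21`: "not active" (no number reported)
Compound 2 `Cc1cc(-n2cc(C(=O)Nc3cc(F)cc(F)c3)c(=O)c3ccc(N(C)C)nc32)ccc1OCCCCCCC[N+]12CCN(CC1)CC2`: 10.6%
Compound 3 `CN(C)c1ccc2c(=O)c(C(=O)Nc3cc(F)cc(F)c3)cn(-c3ccc(OCCCCCCC[N+]4(C)CCCC4)cc3Cl)c2n1`: "not active" (no number reported)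

Compound 2 is the only one of the three for which a number came back; compound 1 and compound 3 were reported without one, so no ordering among them can be drawn from this assay. Compound 4 `Cc1cc(-n2cc(C(=O)Nc3cc(F)cc(F)c3)c(=O)c3ccc(N(C)C)nc32)ccc1OCCCCCCC[N+]1(C)CCCCC1` is the next compound to be measured. It differs from compound 2 in one place: a group of 7 heavy atoms (6 carbon, 1 nitrogen; one six-membered non-aromatic ring with 1 hetero atom) in place of a group of 8 heavy atoms (6 carbon, 2 nitrogen; 2 six-membered non-aromatic rings with 2 hetero atoms each), on a saturated chain carbon, seven bonds along the chain from an oxygen on an aromatic ring. Among the compounds with values here, no pair of measured compounds shows what such a change does in this assay, so the expectation rests on compound 2 alone. The step from compound 2 to compound 4 is expected to stay within the usual scatter, in either direction, a number 0.6 percentage points lower from compound 2 to compound 4 (within the scatter). Compound 4 is therefore estimated at 10%, with a range from 0% to 25%.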

Compound 4, a percentage reported as inhibition, at one concentration (the size of the read-out at that concentration, not a potency): 33%
Estimate against measurement, compound 4: 23 percentage points below, and the stated range ends below it.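

At this position, on a saturated chain carbon seven bonds along the chain from an oxygen on an aromatic ring, the choice of charged ring group does matter: in this assay the swap gives a number 22.4 percentage points higher from compound 2 to compound 4 (beyond the scatter) and takes the read-out out of the scatter. Both groups carry a net charge of +1, so this gain comes without any change in net charge. Nothing measured here explains the step.

Still open, from the compounds shown here alone, is whether a morpholine ring at the chain end would do as well, and whether a longer chain would keep the gain.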